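This account rests on a few compounds, and the source may have more. Where it says the series, first, only, none or still open, it means among the compounds named here.

In a functional assay on PC-3 cells (Homo sapiens) for inhibition, with a stated time of 72 h (on this read-out higher numbers stand for weaker inhibition and lower numbers for stronger inhibition), compound 1 `CO[C@H]1CC[C@H](CN2C(=O)CNc3ncc(-c4ccc(-c5nc[nH]n5)nc4C)nc32)CC1` gives 142 nM and compound 2 `CO[C@H]1CC[C@@H](CN2C(=O)CNc3ncc(-c4ccc(-c5nc[nH]n5)nc4C)nc32)CC1` gives 24 nM, the lower of the two numbers. Compound 3 `Cc1nc(-c2nc[nH]n2)ccc1-c1cnc2c(n1)N(C(C)C)C(=O)CN2` departs from compound 2 at one place: isopropyl in place of (4-methoxycyclohexyl)methyl on an amide-type nitrogen in a ring. Among the measured compounds shown here, the only measured step, a 5.9-fold lower number from compound 1 to compound 2 (0.77 log units; beyond the scatter), is modest and rests on the fact that compounds 1 and 2 differ only in the configuration as drawn within that same group. A step of similar size towards a higher number is therefore expected in this assay. Compound 3 is estimated at 90 nM, with a range of 30 nM to 300 nM. This expectation amounts to a 3.8-fold higher number from compound 2 to compound 3 (0.57 log units; beyond the scatter).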

Compound 3, half-maximal inhibitory concentration: 149 nM
Estimate against measurement, compound 3: 1.7-fold (0.22 log units) below; low and high end bracket the measured number.
By their numbers in this assay, from the lowest: compound 2; then compounds 1 and 3 (each within the scatter of the next).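

At this ring nitrogen, isopropyl falls short of the better of the two (4-methoxycyclohexyl)methyl forms, a 6.2-fold higher number from compound 2 to compound 3 (0.79 log units; beyond the scatter), yet it cannot be told apart from the other form, a 1.0-fold higher number from compound 1 to compound 3 (0.02 log units; within the scatter). The larger group therefore goes with a lower number only in the configuration of compound 2. Its advantage over isopropyl depends on how it is drawn, not on its presence alone: the fact that compounds 1 and 2 differ only in the configuration as drawn

As far as these compounds go, it remains open whether the methoxy oxygen contributes to the lower number of compound 2, as a plain cyclohexylmethyl group or a hydroxyl or amine in place of the methoxy would show. From the compounds shown here alone, it is equally open how a cyclopropylmethyl group or a longer chain such as n-butyl would compare with isopropyl.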